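Amide nitrogen substituents on the shared core

The compounds below may be only part of what the source reports. "The series", "measured", "known", "first", "only" and "open" are said of these compounds alone.

Compound 2 `COc1cc2c(cc1OC)C(CC(=O)NC1CCCCC1)CC2` stands highest of the two numbers in a functional assay on the whole organism (strain Wistar) for inhibition, with Rattus norvegicus as the target, read by paw edema, with stated times of 60 min and 3 h, at a dose of 100 mg/kg by the oral route (on this read-out higher numbers stand for more inhibition at the one dose given (going by the name of the read-out) and lower numbers for less inhibition), where compound 2 gives 49.3%. Compound 1 `COc1cc2c(cc1OC)C(CC(N)=O)CC2` gives 30.4%, and the step of a number 18.9 percentage points higher from compound 1 to compound 2 (beyond the scatter) came with cyclohexyl in place of hydrogen on an amide-type nitrogen. Compound 3 `COc1cc2c(cc1OC)C(CC(=O)NCc1ccccc1)CC2` carries benzyl in place of cyclohexyl on an amide-type nitrogen. Among the measured compounds shown here, no measured step swaps one such group for another; the only step bears on adding a group, not exchanging it. Compound 3 is therefore expected to stay close to compound 2, with a step of a number 1.3 percentage points lower from compound 2 to compound 3 (within the scatter) in this assay. For compound 3 the estimate is 48%, within 35% to 60%.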

Compound 3, a percentage reported as inhibition, in the whole organism at one dose (the size of the read-out at that dose, not a potency): 14.5%
Beside the measured number, compound 3's estimate is 33.5 percentage points above it; measured number outside the range, below it.
By their numbers in this assay, from the lowest: compound 3; then compound 1; then compound 2.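

On the amide-type nitrogen, the kind of group sets the direction of the change: benzyl in place of cyclohexyl gives a number 34.8 percentage points lower from compound 2 to compound 3 (beyond the scatter) and benzyl in place of hydrogen gives a number 15.9 percentage points lower from compound 1 to compound 3 (beyond the scatter) in this assay as the read-out. Substitution on this nitrogen therefore does not by itself raise the number, and compound 3 goes against the gain seen with compound 2. No available data account for the gap between these two groups.

Left open is whether a cyclohexylmethyl or a phenyl group on the same nitrogen would stay nearer compound 2 or compound 3, which would separate the aromatic ring from the added carbon of benzyl.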